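Bromophenyl Urea in Place of Cinnamoyl: Cytotoxicity Expected

The compounds below may be only part of what the source reports. "The series", "measured", "known", "first", "only" and "open" are said of these compounds alone.

Measured so far:
Compound 1 `COc1cc(NC(C)CCCNC(=O)/C=C/c2ccc(OC)c(OC)c2)c2ncccc2c1`: in an ADME assay on L6 cells (Rattus norvegicus) for cytotoxicity, read by resazurin assay, with a stated time of 70 h (a lower number here means a stronger inhibitor, a higher number a weaker inhibitor), compound 1 gives > 220000 nM, which is a limit of the assay rather than a number.
Compound 2 `COc1cc(NC(C)CCCNC(=O)/C=C/c2ccc(Cl)cc2)c2ncccc2c1`: compound 2 gives 16800 nM.
Compound 3 `COc1cc(NC(C)CCCNC(=O)NNC(=O)/C=C/c2ccccc2)c2ncccc2c1`: compound 3 gives 13900 nM.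

Compound 3 stands at the lowest of the two numbers, but compound 2 sits within the scatter of it, so no order between them can be claimed. Going by the values given here, the only measured step is an at least 13-fold lower number from compound 1 to compound 2 (1.11 log units; beyond the scatter), a large one, yet it changes the aryl group at the end of the chain, not the part altered here.

Compound 4 `COc1cc(NC(C)CCCNC(=O)NNC(=O)Nc2ccc(Br)cc2)c2ncccc2c1` differs from compound 3 by (4-bromophenyl)amino in place of 2-phenylethenyl on a carbonyl carbon. Among the compounds with values here, no measured step covers this change, so the expected step is a 1.2-fold lower number from compound 3 to compound 4 (0.06 log units; within the scatter), within the scatter. The estimate for compound 4 is 12000 nM, with a range from 3500 nM to 45000 nM.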

Compound 4, half-maximal inhibitory concentration: 38700 nM
For compound 4 the middle estimate is 3.2-fold (0.51 log units) below the measured one, and the stated range covers the measured number.
By their numbers in this assay, from the lowest: compounds 3 and 2 (each within the scatter of the next); then compound 4. At a limit, above all of these: compound 1.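

In this assay, putting (4-bromophenyl)amino in place of 2-phenylethenyl on this carbonyl carbon gives a 2.8-fold higher number from compound 3 to compound 4 (0.44 log units; beyond the scatter). This is the first step shown at this place, and it shows that the number responds to a change here, though only modestly. No measurement shown here explains this step.

The bromine and the amino nitrogen enter in the same change, and the compounds shown cannot separate them. Going by these compounds, how a plain phenylamino group on this carbonyl carbon would read remains open.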